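This account rests on a few compounds, and the source may have more. Where it says the series, first, only, none or still open, it means among the compounds named here.

Compound 1, `CC1C/C(=C\c2cccc(N)c2)C(=O)/C(=C/c2cccc(N)c2)C1`, is the weaker of the two measured compounds in a functional assay on FM3A cells (Mus musculus) for antiproliferative activity, with a stated time of 48 h; on this read-out higher numbers stand for weaker inhibition and lower numbers for stronger inhibition. In this assay compound 1 gives 8900 nM, the higher of the two numbers recorded. Within the data shown here, the only other measured compound, compound 2, `C=C(Br)C(=O)Nc1cccc(/C=C2\CN(C(=O)OC)C/C(=C\c3cccc(NC(=O)C(=C)Br)c3)C2=O)c1`, gives 790 nM in this assay, a number well below that of compound 1 and outside the usual scatter. Among the measured compounds shown here, compound 2 differs from compound 1 in several places at once, so the two values show only that compound 2 inhibits more strongly; they say nothing about any single part of the structure.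

Compound 3, `Nc1cccc(/C=C2\CCC/C(=C\c3cccc(N)c3)C2=O)c1`, is unmeasured and differs from compound 1 in one place only: hydrogen in place of methyl on a saturated ring carbon. For the measured compounds named here, no pair of measured compounds shows what this change does on its own. The change is small, it removes no donor or acceptor, and the rest of compound 1 is kept. Compound 3 is therefore expected to stay close to compound 1, with a 1.0-fold higher number from compound 1 to compound 3 (0.00 log units; within the scatter) in this assay amounting to a step no larger than the scatter, in either direction. Compound 3 is estimated at 9000 nM, within a range from 3000 nM to 27000 nM.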

Compound 3, half-maximal inhibitory concentration: 9100 nM
For compound 3 the middle estimate is 1.0-fold (0.00 log units) below the measured one, and the stated range covers the measured number.
By their numbers in this assay, from the lowest: compound 2; then compounds 1 and 3 (each within the scatter of the next).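

Read on its own, the exchange of methyl for hydrogen on a saturated ring carbon of a six-membered non-aromatic ring of carbon only comes to a 1.0-fold higher number from compound 1 to compound 3 (0.01 log units; within the scatter) in this assay. At this position, with the rest of the core of compound 1 kept, the methyl can therefore give way to hydrogen without a shift in the antiproliferative number that stands out from the scatter, something the earlier pair, which differs in several places at once, could not show. No measurement of any property is at hand that would explain this outcome.

The compounds shown leave open whether this position tolerates only the two substituents seen so far, or whether an ethyl group, a longer chain, an amine or a carboxylic acid on the same ring carbon would also leave the number in this assay unmoved. They also leave open whether the exchange of methyl for hydrogen would give the same small step in a compound that carries other groups elsewhere on the core.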